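Swapping the amine on a shared core: from compound 2 to compound 3

The source may hold more compounds than are shown below. What is called first, only, known or untested is meant among the compounds shown, and "the series" means these compounds.

Compound 1 `CC(C)c1ccc(-c2nc(N)c3cc(CN4[C@H](C)CCC[C@@H]4C)sc3n2)o1`: 140 nM
Compound 2 `N#Cc1cccc(-c2nc(N)c3cc(CN4CC=CC4)sc3n2)c1`: 2070 nM

In an assay on CHO-K1 cells for antagonist activity at adenosine receptor A1 (Homo sapiens), read by a beta-galactosidase reporter, with stated times of 15 min and 6 h (on this read-out higher numbers stand for weaker inhibition and lower numbers for stronger inhibition), compound 2 gives 2070 nM, the higher of the two numbers, and its gap to compound 1 lies beyond the usual scatter. Compound 3 `C[C@@H]1CCC[C@H](C)N1Cc1cc2c(N)nc(-c3cccc(C#N)c3)nc2s1` keeps the nitrile-bearing aryl of compound 2 but carries the amine of compound 1: a group of 8 heavy atoms (7 carbon, 1 nitrogen; one six-membered non-aromatic ring with 1 hetero atom) in place of a group of 5 heavy atoms (4 carbon, 1 nitrogen; one five-membered non-aromatic ring with 1 hetero atom), on a saturated chain carbon bound to an aromatic carbon. With compound 1 giving 140 nM in this assay, the expectation for compound 3 is a step downwards beyond the scatter, a 4.1-fold lower number from compound 2 to compound 3 (0.62 log units; beyond the scatter). Compound 3 is therefore estimated at 500 nM, within a range of 150 nM to 1600 nM.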

Compound 3, inhibition constant: 460 nM
Estimate against measurement, compound 3: 1.1-fold (0.04 log units) above, within the range that was stated.
By their numbers in this assay, from the lowest: compound 1; then compound 3; then compound 2.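

Compound 3 separates two changes that compound 1 and compound 2 left tangled. With the 3-cyanophenyl group held fixed, the 2,6-dimethylpiperidin-1-yl group alone gives a 4.5-fold lower number from compound 2 to compound 3 (0.65 log units; beyond the scatter) in this assay. With that amine held fixed, 3-cyanophenyl in place of 5-isopropylfuran-2-yl gives a 3.3-fold higher number from compound 1 to compound 3 (0.52 log units; beyond the scatter), so each of the two places moves the number on its own. Nothing here explains either step. Still open, on these data alone, is whether the ring size, the methyl groups or their stereocentres matter most, which plain piperidin-1-yl, without methyl groups, would help to separate.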